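A few compounds are considered here, and "the series" means these few. Any claim that something is new, unique, unknown or untested is made for them only; others in the source may bear on it.

In a functional assay on HepG2 cells (Homo sapiens) for inhibition, read by MTT assay, with a stated time of 48 h (a lower number here means a stronger inhibitor, a higher number a weaker inhibitor), compound 3 `COc1cc(-c2nnc(SC)n2-c2ccc(N(C)C)cc2)cc(OC)c1OC` gives > 60000 nM, which is a limit and not a number. Compound 1 `COc1ccc(-n2c(SC)nnc2-c2cc(OC)c(OC)c(OC)c2)cc1` gives > 60000 nM, also a limit. Compound 2 `COc1ccc(-n2c(SCC(=O)c3ccccc3)nnc2-c2cc(OC)c(OC)c(OC)c2)cc1` gives 16200 nM.

Compound 4 `COc1ccc(C(=O)CSc2nnc(-c3cc(OC)c(OC)c(OC)c3)n2-c2ccc(N(C)C)cc2)cc1` differs from compound 3 by (4-methoxyphenyl)carbonyl in place of hydrogen on a saturated chain carbon bound to a sulfur. The closest measured precedent is an at least 3.7-fold lower number from compound 1 to compound 2 (0.56 log units; beyond the scatter), with benzoyl in place of hydrogen at that same kind of carbon. The other measured change, a step that the two limits leave unreadable from compound 1 to compound 3, gives no size to carry over.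

On that single precedent, the expected change in this assay is a move to a lower number, an at least 4.2-fold lower number from compound 3 to compound 4 (0.63 log units; beyond the scatter). Compound 4 is estimated at 14000 nM, with an expected range from 5000 nM to 40000 nM.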

Compound 4, half-maximal inhibitory concentration: 18800 nM
Estimate against measurement, compound 4: 1.3-fold (0.13 log units) below; measured number inside the range.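

In this assay, (4-methoxyphenyl)carbonyl on the saturated chain carbon bound to a sulfur gives an at least 3.1-fold lower number from compound 3 to compound 4 (0.50 log units; beyond the scatter), so a gain of the kind seen with benzoyl at compound 2 also appears in a compound carrying dimethylamino in place of methoxy. Compound 3 stands at a limit, so this step fixes only a minimum size: the limit of > 60000 nM in this assay, at which 2 of the 4 values shown sit.

Compound 2 and compound 4 differ in two places, so neither change can be read alone between them. On these data alone, whether an amine, a carboxylic acid or a longer chain at this carbon would keep the step remains open.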